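The source may hold more compounds than are shown below. What is called first, only, known or untested is meant among the compounds shown, and "the series" means these compounds.

Of the compounds shown here, two of a shared core have been measured in an assay on isolated protein for inhibition of aldehyde dehydrogenase 1A1 (Homo sapiens), read by spectrophotometry, tested at 10 uM; a higher number here means more inhibition at the concentration tested (going by the name of the read-out), a lower number less inhibition. Compound 1 `CC(C)=CCn1c(CN2CCN(C(=O)C3CC3)CC2)nc2ccccc21` gives 74.3% in this assay, and compound 2 `Cc1cccc(Cn2c(CN3CCN(C(=O)c4ccncc4)CC3)nc3ccccc32)c1` gives 20.6%. Compound 2 thus stands lowest of the two numbers shown, with compound 1 sitting far above it, a gap well beyond the scatter of repeated measurements. Going by the values given here, compound 1 and compound 2 differ in more than one place, so no single step can be drawn between them.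

Compound 3 `Cc1cccc(Cn2c(CN3CCN(C(=O)C4CCC4)CC3)nc3ccccc32)c1` has not yet been measured. It comes from compound 2 by one change: cyclobutyl in place of pyridin-4-yl on a carbonyl carbon. The amide-type nitrogen in the ring and the rest of the molecule stay as they are in compound 2.

Because compound 1 reaches 74.3% in this assay, high inhibition is clearly attainable in this series, and the replacement of the aromatic pyridin-4-yl by a small carbon-only cyclobutyl ring is expected to move the number upward, though by an uncertain amount. The step from compound 2 to compound 3 is expected to be a number 24.4 percentage points higher from compound 2 to compound 3 (beyond the scatter). Compound 3 is therefore estimated at 45%, within a range from 20% to 72%.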

Compound 3, a percentage reported as inhibition, at one concentration (the size of the read-out at that concentration, not a potency): 69.1%
Compound 3: middle estimate off by 24.1 percentage points, on the low side, within the range that was stated.
By their numbers in this assay, from the lowest: compound 2; then compounds 3 and 1 (each within the scatter of the next).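

In this assay, going by these compounds alone, putting cyclobutyl in place of pyridin-4-yl on a carbonyl carbon gives a number 48.5 percentage points higher from compound 2 to compound 3 (beyond the scatter), the first step in this set that changes only one place. This shows that the read-out responds strongly to the group on this carbonyl carbon when the rest of compound 2 stays as it is. The change replaces a six-membered aromatic ring carrying one nitrogen and one hydrogen-bond acceptor with a four-membered ring of carbon only, and no measurement at hand explains why the number moves.

This single step changes ring size, aromatic character and the ring nitrogen all at once, so it cannot show which of these differences matters. A phenyl group on the same carbonyl carbon would keep the six-membered aromatic ring without the ring nitrogen, while a cyclohexyl group would keep the six-membered size in a non-aromatic ring of carbon only, and each would help to separate these differences.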